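The source may hold more compounds than are shown below. What is called first, only, known or untested is meant among the compounds shown, and "the series" means these compounds.

Of the compounds shown here, three sharing one amide core have been measured in an assay on C3H 10T1/2 cells for inhibition of Sonic hedgehog protein (Mus musculus), read by a luciferase reporter; on this read-out higher numbers stand for weaker inhibition and lower numbers for stronger inhibition. Compound 1 `Cc1nc(C(F)(F)F)ccc1C(=O)Nc1ccc(Cl)c(-c2cc3ccccc3[nH]2)c1` gives 500 nM, compound 2 `Cc1nc(C(F)(F)F)ccc1C(=O)Nc1ccc(Cl)c(-c2nc3ccccc3s2)c1` gives 70 nM, and compound 3 `Cc1nc(C(F)(F)F)ccc1C(=O)Nc1ccc(Cl)c(-c2ccn(C)n2)c1` gives 550 nM. On these numbers compound 3 stands highest, though its gap to compound 1 is within the scatter, while the step of a 7.9-fold higher number from compound 2 to compound 3 (0.90 log units; beyond the scatter) lies beyond it, so the benzothiazole of compound 2 sets the strongest result seen so far.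

Compound 4 `Cc1nc(C(F)(F)F)ccc1C(=O)Nc1ccc(Cl)c(-c2cccnc2)c1` is not yet measured. It differs from compound 3 in one place: pyridin-3-yl in place of 1-methyl-1H-pyrazol-3-yl on an aromatic carbon. Going by the values given here, no measured step swaps one single-ring group for another, so the guide is indirect. The step of a 1.1-fold higher number from compound 1 to compound 3 (0.04 log units; within the scatter) shows that two quite different groups on this aromatic carbon can give numbers within the scatter of each other, whereas a 7.9-fold higher number from compound 2 to compound 3 (0.90 log units; beyond the scatter) shows that the choice of group can also matter modestly. With a single-ring group entering in place of a single-ring group, only a small step is expected in this assay, a 1.4-fold lower number from compound 3 to compound 4 (0.14 log units; within the scatter), direction uncertain. Compound 4 is therefore estimated at 400 nM, expected to fall between 120 nM and 1300 nM.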

Compound 4, half-maximal inhibitory concentration: 10000 nM
Beside the measured number, compound 4's estimate is 25-fold (1.40 log units) below it, and the stated range ends below it.
By their numbers in this assay, from the lowest: compound 2; then compounds 1 and 3 (each within the scatter of the next); then compound 4.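

In this assay, going by these compounds alone, this aromatic carbon, ortho to a chloro group, does not treat all single-ring groups alike: pyridin-3-yl in place of 1-methyl-1H-pyrazol-3-yl gives an 18-fold higher number from compound 3 to compound 4 (1.26 log units; beyond the scatter), a large step where the earlier compounds showed none larger than modest. The pyridin-3-yl group also falls far short of both fused groups, with a 140-fold higher number from compound 2 to compound 4 (2.15 log units; beyond the scatter) and a 20-fold higher number from compound 1 to compound 4 (1.30 log units; beyond the scatter). Heavy-atom count alone does not set the result here, since the groups of compound 3 and compound 4 match in that count yet differ widely.

Nothing shown here explains this loss. Going by these compounds, whether the six-membered ring or the place of its nitrogen matters stays open, and a plain phenyl or a pyridin-4-yl group on this carbon would help separate the two.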